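Compound 4: fluoro to hydrogen on the pendant aryl ring

The source may report more compounds than this note shows. Statements on the series, on what has been measured and on what is new or still open speak of the compounds shown alone.

Compound 1 `COc1cc2c(Oc3ccc(NC(=O)c4cc(-c5ccc(F)cc5)ccn4)cc3F)ccnc2cc1OCCCN1CCCCC1`: 10100 nM
Compound 3 `COc1cc2c(Oc3ccc(NC(=O)c4cc(-c5ccc(F)cc5)ccn4)cc3F)ccnc2cc1OCCCN1CCCC1`: 1800 nM
Compound 2 `COc1cc2c(Oc3ccc(NC(=O)c4cc(-c5ccc(F)cc5)ccn4)cc3F)ccnc2cc1OCCCN1CCN(C)CC1`: "not determined" (no result reported)

In a functional assay on A549 cells (Homo sapiens) for cytotoxicity, read by MTT assay, with a stated time of 72 h (a higher number here means a weaker inhibitor, a lower number a stronger inhibitor), compound 1 gives 10100 nM, the higher of the two numbers available; compound 3 gives 1800 nM. Compound 2 gives "not determined" (no result reported), so no number exists for it. Among the compounds with values here, the only measured step is a 5.6-fold lower number from compound 1 to compound 3 (0.75 log units; beyond the scatter), a change at the amine on the saturated chain. Compound 4 `COc1cc2c(Oc3ccc(NC(=O)c4cc(-c5ccccc5)ccn4)cc3F)ccnc2cc1OCCCN1CCCCC1` differs from compound 1 by hydrogen in place of fluoro on an aromatic carbon, on an aromatic carbon para to a large group; cut one bond further out, 4-fluorophenyl becomes phenyl. Within the data shown here, no measured step touches this position, so no step beyond the scatter is expected: the estimated step is a 1.0-fold lower number from compound 1 to compound 4 (0.00 log units; within the scatter). Compound 4 is therefore expected near 10000 nM, within 4000 nM to 25000 nM.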

Compound 4, half-maximal inhibitory concentration: 1800 nM
Estimate against measurement, compound 4: 5.6-fold (0.74 log units) above, and the stated range ends above it.
By their numbers in this assay, from the lowest: compounds 3 and 4 (each within the scatter of the next); then compound 1.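

In this assay the fluoro on the pendant aryl ring proves to matter, since 4-fluorophenyl to phenyl gives a 5.6-fold lower number from compound 1 to compound 4 (0.75 log units; beyond the scatter) in compound 4. Within the data shown here, this is the first measured change at this position, and it shows that the amine on the saturated chain is not the only site in compound 1 where one change moves the number beyond the scatter. Nothing measured here accounts for the step.

The compounds shown leave open how chloro or methoxy would behave on the same aromatic carbon. They also leave open whether phenyl in place of 4-fluorophenyl would give a similar step alongside the pyrrolidin-1-yl group of compound 3.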